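Thiourea series: aryl change from compound 2 to compound 3

The compounds below may be only part of what the source reports. "The series", "measured", "known", "first", "only" and "open" are said of these compounds alone.

Measured so far:
compound 1 `CNC(=O)c1cc(Oc2cccc(NC(=S)Nc3ccc(Cl)cc3Cl)c2)ccn1`: 37800 nM
compound 2 `CNC(=O)c1cc(Oc2cccc(NC(=S)Nc3ccc(Cl)cc3)c2)ccn1`: 24100 nM

In a functional assay on PC-3 cells (Homo sapiens) for cytotoxicity, read by MTT assay, with a stated time of 48 h (on this read-out higher numbers stand for weaker inhibition and lower numbers for stronger inhibition), compound 1 gives 37800 nM and compound 2 gives 24100 nM. Of the two numbers that of compound 2 is the lowest, but the step of a 1.6-fold lower number from compound 1 to compound 2 (0.20 log units; within the scatter) lies within the scatter, so the two compounds are not separated by this assay.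

Compound 3 `CNC(=O)c1cc(Oc2cccc(NC(=S)Nc3ccc(F)c(F)c3)c2)ccn1` is not yet measured. It differs from compound 2 by 3,4-difluorophenyl in place of 4-chlorophenyl on an amide-type nitrogen. Within the data shown here, the only measured step that bears on a change of the halogen pattern on this ring is a 1.6-fold lower number from compound 1 to compound 2 (0.20 log units; within the scatter), and that step stayed within the scatter. On that basis no step beyond the scatter is expected from compound 2 to compound 3 in this assay.

Compound 3 is therefore expected to give about 26000 nM in this assay, with a range of 10000 nM to 65000 nM, which means an expected step of a 1.1-fold higher number from compound 2 to compound 3 (0.03 log units; within the scatter).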

Compound 3, half-maximal inhibitory concentration: 33100 nM
The estimate for compound 3 lay 1.3-fold (0.10 log units) below the measured number; the range from low to high includes it.
By their numbers in this assay, from the lowest: compounds 2, 3 and 1 (each within the scatter of the next).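

In this assay, 3,4-difluorophenyl on the amide-type nitrogen gives a 1.4-fold higher number from compound 2 to compound 3 (0.14 log units; within the scatter), and the same group set against 2,4-dichlorophenyl gives a 1.1-fold lower number from compound 1 to compound 3 (0.06 log units; within the scatter). The earlier compounds shown here showed only the loss of one chloro from this ring; these steps extend the finding to a change of halogen and of substitution pattern, and the three aryl groups still remain unseparated by this assay. No supporting measurement accompanies these results, and the data give no cause for them.

The compounds shown carry only chloro and fluoro on this ring, so it remains open whether a methoxy group, a dimethylamino group or a carboxylic acid there would give a step beyond the scatter. Also open, going by these compounds, is how the urea counterpart of the thiourea would read in this assay.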